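The source may report more compounds than this note shows. Statements on the series, on what has been measured and on what is new or still open speak of the compounds shown alone.

Measured so far:
Compound 1, `S=C(Nc1ccccc1)N1N=C(c2ccc(Br)cc2)CC1c1ccc2c(c1)OCCO2`, gives 470 nM in a functional assay on A-375 cells (Homo sapiens) for antiproliferative activity, read by MTT assay, with a stated time of 48 h; on this read-out higher numbers stand for weaker inhibition of growth and lower numbers for stronger inhibition of growth.
Compound 2, `S=C(Nc1ccccc1)N1N=C(c2ccccc2Br)CC1c1ccc2c(c1)OCCO2`, gives > 200000 nM in this assay, which is a limit of the assay and not a number.

Compound 2 therefore stands at the weak end of the two values shown. Among the compounds with values here, the only measured step, an at least 420-fold higher number from compound 1 to compound 2 (2.62 log units; beyond the scatter), is a large loss: exchanging a 4-bromophenyl for a 2-bromophenyl on the carbon with a double bond to nitrogen carries the value all the way to the limit of > 200000 nM in this assay, at which 1 of the 2 values shown sits, so the true size of that loss is not known. Compound 3, `S=C(Nc1ccccc1)N1N=C(c2cccs2)CC1c1ccc2c(c1)OCCO2`, differs from compound 2 by thiophen-2-yl in place of 2-bromophenyl on a carbon with a double bond to nitrogen. The measured step bears directly on this position, since it shows that the 2-bromophenyl, not the shared core, is what sits behind the limit. Compound 3 carries no bromine on the group at that carbon, so a return towards the range of compound 1 is expected, though the thiophen-2-yl is a new group without a measured counterpart here. Compound 3 is expected to give about 2000 nM, in a range from 300 nM to 40000 nM. The expected step is an at least 100-fold lower number from compound 2 to compound 3 (2.00 log units; beyond the scatter).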

Compound 3, concentration for 50% growth inhibition: 121000 nM
For compound 3 the middle estimate is 61-fold (1.78 log units) below the measured one, outside the stated range (above it).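

Thiophen-2-yl in place of 4-bromophenyl on the carbon with a double bond to nitrogen is a large loss in this assay (a 260-fold higher number from compound 1 to compound 3 (2.41 log units; beyond the scatter)), and this gives the position a loss measured as a number rather than one ending at a limit. The absence of bromine from the group at this carbon therefore does not bring the value back towards that of compound 1: among the three groups shown, only 4-bromophenyl goes with strong inhibition of growth, while 2-bromophenyl and thiophen-2-yl both go with much weaker inhibition. From the compounds shown here alone, the value of compound 2 is a limit of the assay and not a number, so the step to the thiophene (an at least 1.6-fold lower number from compound 2 to compound 3 (0.21 log units; that floor lies within the scatter)) gives only a floor, and its true size stays unknown because of where compound 2 lies: the limit of > 200000 nM in this assay, at which 1 of the 3 values shown sits.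

The compounds shown leave open whether the bromine or the phenyl ring matters more for the value of compound 1, a question that plain phenyl, 4-chlorophenyl or 4-methoxyphenyl at this carbon would address. They also leave open how 3-bromophenyl would compare with the 2-bromophenyl and 4-bromophenyl groups.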